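Extending an amino-bearing chain on a shared core

A few compounds are considered here, and "the series" means these few. Any claim that something is new, unique, unknown or untested is made for them only; others in the source may bear on it.

Compound 1 `COc1cc(-c2oc3ccccc3c(=O)c2OC(C)C)cc(OC)c1OC` carries an isopropyl group on an oxygen on an aromatic ring of the shared core. Among the measured compounds shown here, in a functional assay on PC-3 cells (Homo sapiens) for antiproliferative activity, read by WST assay, with a stated time of 3 days (on this read-out higher numbers stand for weaker inhibition and lower numbers for stronger inhibition), compound 1 gives 21200 nM, the highest of the three numbers measured so far. Compound 2 `CCN(CC)CCCOc1c(-c2cc(OC)c(OC)c(OC)c2)oc2ccccc2c1=O` gives 13600 nM, and compound 3 `CCCN(CCC)CCCCCOc1c(-c2cc(OC)c(OC)c(OC)c2)oc2ccccc2c1=O` gives 2600 nM. The step of a 1.6-fold lower number from compound 1 to compound 2 (0.19 log units; within the scatter) stays within the scatter, whereas an 8.2-fold lower number from compound 1 to compound 3 (0.91 log units; beyond the scatter) and a 5.2-fold lower number from compound 2 to compound 3 (0.72 log units; beyond the scatter) are modest but real. Compound 4 `CCCCN(CCCC)CCCOc1c(-c2cc(OC)c(OC)c(OC)c2)oc2ccccc2c1=O` is the next member: 3-(dibutylamino)propyl in place of isopropyl on an oxygen on an aromatic ring. Both measured steps from compound 1 bear on this change, since each also puts a chain bearing a nitrogen on that oxygen, and the larger replacement in compound 3 brought the bigger drop. Compound 4 keeps the propyl portion of the chain seen in compound 2 but carries the larger dibutylamino group, so a lowering in this assay beyond the scatter is expected, though likely short of what compound 3 reached. The estimate for compound 4 is 5500 nM, with a range from 1800 nM to 16000 nM, an expected step of a 3.9-fold lower number from compound 1 to compound 4 (0.59 log units; beyond the scatter).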

Compound 4, half-maximal inhibitory concentration: 7100 nM
Estimate against measurement, compound 4: 1.3-fold (0.11 log units) below; measured number inside the range.
By their numbers in this assay, from the lowest: compound 3; then compounds 4, 2 and 1 (each within the scatter of the next, the first and the last beyond it).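

In this assay, 3-(dibutylamino)propyl on the oxygen gives a 3.0-fold lower number from compound 1 to compound 4 (0.48 log units; beyond the scatter), so a drop beyond the scatter from the isopropyl of compound 1 does not depend on the 5-(dipropylamino)pentyl chain of compound 3. Yet dibutylamino in place of diethylamino on the same propyl chain gives a 1.9-fold lower number from compound 2 to compound 4 (0.28 log units; within the scatter), which stays within the scatter, while a 2.7-fold higher number from compound 3 to compound 4 (0.44 log units; beyond the scatter) shows that compound 3 keeps a real edge over compound 4. Nothing available explains these differences.

Compound 3 and compound 4 differ in both chain length and the alkyl groups on the nitrogen, so the compounds shown do not separate these two changes; a 5-(dibutylamino)pentyl chain would bear directly on that. As far as these compounds go, how a cyclic amine such as piperidine on the propyl chain would compare also remains open.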